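The compounds below may be only part of what the source reports. "The series", "measured", "known", "first", "only" and "open" are said of these compounds alone.

Compound 2 `O=C(Nc1cccc([N+](=O)[O-])c1)N1CCN(S(=O)(=O)c2sccc2-c2ccccc2Oc2ccc(O)c(O)c2)CC1` carries a 3,4-dihydroxyphenyl group on an oxygen on an aromatic ring. In a functional assay on HL-60 cells (Homo sapiens) for inhibition, read by CCK-8 assay, with a stated time of 48 h (on this read-out lower numbers stand for stronger inhibition and higher numbers for weaker inhibition), compound 2 gives 4500 nM. Among the numbers shown this is the lower of two, and it sits close to compound 3 `O=[N+]([O-])c1ccc(NC(=S)N2CCN(S(=O)(=O)c3sccc3-c3ccccc3Oc3ccc(O)c(O)c3)CC2)cc1`, which gives 5300 nM in this assay. The step of a 1.2-fold higher number from compound 2 to compound 3 (0.07 log units; within the scatter) changes only a group on an amine nitrogen in a ring and stays within the scatter. Compound 1 `COc1ccc(Oc2ccccc2-c2ccsc2S(=O)(=O)N2CCN(C(=O)Nc3ccc([N+](=O)[O-])cc3)CC2)cc1OC` reaches only > 50000 nM in this assay, which is a limit of the assay and not a number. Compound 4 `COc1ccc(Oc2ccccc2-c2ccsc2S(=O)(=O)N2CCN(C(=O)Nc3cccc([N+](=O)[O-])c3)CC2)cc1OC` has not yet been measured. It differs from compound 2 in one place: 3,4-dimethoxyphenyl in place of 3,4-dihydroxyphenyl on an oxygen on an aromatic ring. No measured step touches this group, so the one step shown, from compound 2 to compound 3, does not bear on it. For the measured compounds named here, because the limit of > 50000 nM in this assay, at which 1 of the 3 values shown sits, is where the single compound carrying a 3,4-dimethoxyphenyl group stands, a move toward weaker inhibition is expected. Compound 4 is therefore estimated at 30000 nM, within 8000 nM to 100000 nM. The step of a 6.7-fold higher number from compound 2 to compound 4 (0.82 log units; beyond the scatter) states this expectation.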

Compound 4, half-maximal inhibitory concentration: > 50000 nM
Compound 4 ended at the assay's limit; the forecaster's own chance of this, stated with the estimate: 45%; at least 1.6-fold (0.22 log units) between middle value and limit.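

In this assay, replacing 3,4-dihydroxyphenyl with 3,4-dimethoxyphenyl on an oxygen on an aromatic ring gives an at least 11-fold higher number from compound 2 to compound 4 (1.04 log units; beyond the scatter), so this position, untouched by any earlier readable step, clearly matters in this assay. Compound 1 and compound 4, the two compounds carrying 3,4-dimethoxyphenyl, now both stand at a limit of the assay and not at a number: the limit of > 50000 nM in this assay, at which 2 of the 4 values shown sit. The swap of 3-nitrophenyl for 4-nitrophenyl between these two compounds cannot be read, as the two limits hide any difference.

The compounds shown leave open whether both hydroxyl groups are needed, or whether a phenyl group carrying a single hydroxyl would hold the level of compound 2. They also do not show whether an amine in place of the two hydroxyl groups would serve at this position.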